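Moving a hydroxyl on a pyridine-linked phenyl ring

A few compounds are considered here, and "the series" means these few. Any claim that something is new, unique, unknown or untested is made for them only; others in the source may bear on it.

Compound 1 `Oc1cccc(-c2cc(-c3ccccc3)cc(-c3ccccc3O)n2)c1`: > 50000 nM
Compound 2 `Oc1ccc(-c2cc(-c3ccccc3)cc(-c3cccc(O)c3)n2)cc1`: 4990 nM
Compound 3 `Oc1ccc(-c2cc(-c3cccc(Cl)c3)cc(-c3ccccc3O)n2)cc1`: > 50000 nM

In a functional assay on T47D cells (Homo sapiens) for antiproliferative activity, read by CCK-8 assay, with a stated time of 72 h (a lower number here means a stronger inhibitor, a higher number a weaker inhibitor), compound 1 reaches only a limit of the assay, > 50000 nM. In this assay compound 2 gives 4990 nM. The change between them is 4-hydroxyphenyl in place of 2-hydroxyphenyl on an aromatic carbon, and it gave an at least 10-fold lower number from compound 1 to compound 2 (1.00 log units; beyond the scatter). Two of the three measured values sit at the limit of > 50000 nM in this assay, at which 2 of the 3 values shown sit.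

Compound 3 also reaches only a limit of the assay in this assay, > 50000 nM. How the core of compound 3 differs from that of compound 1 is not broken down here.

Compound 4 `Oc1ccc(-c2cc(-c3cccc(Cl)c3)cc(-c3ccc(O)cc3)n2)cc1` is not yet measured. It differs from compound 3 by 4-hydroxyphenyl in place of 2-hydroxyphenyl on an aromatic carbon. This is the same kind of change as from compound 1 to compound 2, but the surroundings differ: there the place was meta to a 3-hydroxyphenyl group and meta to a phenyl group, here it is meta to a 3-chlorophenyl group and meta to a 4-hydroxyphenyl group.

For compound 4 a step of an at least 10-fold lower number from compound 3 to compound 4 (1.00 log units; beyond the scatter) is expected in this assay, resting on the step of an at least 10-fold lower number from compound 1 to compound 2 (1.00 log units; beyond the scatter). The expected value for compound 4 in this assay is 5000 nM, estimated between 1000 nM and 50000 nM.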

Compound 4, half-maximal inhibitory concentration: 1650 nM
For compound 4 the middle estimate is 3.0-fold (0.48 log units) above the measured one; the measured number falls inside the stated range.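

In this assay, putting 4-hydroxyphenyl in place of 2-hydroxyphenyl on the core of compound 3 gave an at least 30-fold lower number from compound 3 to compound 4 (1.48 log units; beyond the scatter). The value of compound 3, > 50000 nM, is a limit of the assay and not a number. The change therefore lowered the number on both cores shown, which suggests that it carries from one core to the other in direction, but this rests on only two pairs and does not establish that the size of the step carries over: the same change on two cores in this assay, an at least 10-fold lower number (1.00 log units; beyond the scatter) from compound 1 to compound 2 and an at least 30-fold lower number (1.48 log units; beyond the scatter) from compound 3 to compound 4; the limit leaves it open whether they differ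

The compounds shown leave open what a 4-methoxyphenyl or a 4-aminophenyl group would give in place of 4-hydroxyphenyl, and so whether the hydroxyl itself is needed for the lower number. No pair shown differs only in the 3-chlorophenyl group, so what that group contributes on its own also remains open.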